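Aryl variation on the shared core and cell inhibition

The compounds below may be only part of what the source reports. "The series", "measured", "known", "first", "only" and "open" are said of these compounds alone.

Measured so far:
compound 1 `CC/C(=C(/c1ccc(/C=C/C(=O)O)cc1)c1cc2ccccc2[nH]1)c1ccc(F)cc1Cl` with 39 nM
compound 2 `CC/C(=C(/c1ccc(/C=C/C(=O)O)cc1)c1cc2ccccc2[nH]1)c1ccc(Cl)cc1C(F)(F)F` with 4 nM

Both numbers come from a functional assay on MCF7 cells (Homo sapiens) for inhibition; on this read-out higher numbers stand for weaker inhibition and lower numbers for stronger inhibition. Among the measured compounds shown here, compound 2 stands lowest of the two, and its only neighbour, compound 1, lies a 9.8-fold lower number from compound 1 to compound 2 (0.99 log units; beyond the scatter) away. Compound 3 `CC/C(=C(/c1ccc(/C=C/C(=O)O)cc1)c1cc2ccccc2[nH]1)c1ccc(Cl)c(C)c1` has not yet been measured. It differs from compound 2 in one place: 4-chloro-3-methylphenyl in place of 4-chloro-2-(trifluoromethyl)phenyl on a double-bonded chain carbon bound to a double-bonded chain carbon and a saturated chain carbon. For the measured compounds named here, the single step that bears on this change is the exchange of one aryl group for another on the same carbon, namely a 9.8-fold lower number from compound 1 to compound 2 (0.99 log units; beyond the scatter), which shows that the substitution pattern of this ring can move the number by a modest amount and well beyond the scatter. Compound 3 keeps the 4-chloro substituent of compound 2 but carries a methyl in place of a trifluoromethyl at a different position. Going by the values given here, with only one relevant step, the direction is uncertain; compound 3 is expected to give a somewhat higher number, a 5.0-fold higher number from compound 2 to compound 3 (0.70 log units; beyond the scatter), estimated at 20 nM with a range from 5 nM to 80 nM.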

Compound 3, half-maximal inhibitory concentration: 840 nM
Compound 3: middle estimate off by 42-fold (1.62 log units), on the low side; the whole stated range lies below it.
By their numbers in this assay, from the lowest: compound 2; then compound 1; then compound 3.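

In this assay the exchange of 4-chloro-2-(trifluoromethyl)phenyl for 4-chloro-3-methylphenyl brings a 210-fold higher number from compound 2 to compound 3 (2.32 log units; beyond the scatter) and is a far larger step than the one seen earlier at this carbon. The 4-chloro substituent shared by these two groups does not by itself keep the number low, and 4-chloro-3-methylphenyl also does worse than 2-chloro-4-fluorophenyl, with a 22-fold higher number from compound 1 to compound 3 (1.33 log units; beyond the scatter) making compound 3 the highest of the three. No measurement shown accounts for the size of these steps.

Still open, from the compounds shown here alone, is which part of the change carries the step, for the methyl and the trifluoromethyl differ both as groups and in their place on the ring. Going by these compounds, whether a 4-chloro-2-methylphenyl or a 4-chloro-3-(trifluoromethyl)phenyl group on this carbon would fall nearer compound 2 or compound 3 remains unknown.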